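The compounds below may be only part of what the source reports. "The series", "measured", "known", "first", "only" and "open" are said of these compounds alone.

Compound 1 `Cc1cc(C#N)cc(C)c1Oc1nc(Nc2ccc(C#N)cc2)ncc1-c1ccncc1` gives 28000 nM in an ADME assay on MT4 cells (Homo sapiens) for cytotoxicity, read by MTT assay, with a stated time of 5 days (a higher number here means that more compound is tolerated, a lower number that less compound is tolerated), the highest of the two numbers in this small set. Compound 2 `Cc1cc(C#N)cc(C)c1Oc1nc(Nc2ccc(C#N)cc2)ncc1-c1ccc2ccccc2c1` gives 8460 nM in this assay; the step is a 3.3-fold lower number from compound 1 to compound 2 (0.52 log units; beyond the scatter). Compound 3 `Cc1cc(C#N)cc(C)c1Oc1nc(Nc2ccc(C#N)cc2)ncc1-c1ccco1` in this assay sits at an assay limit, > 306000 nM, not a number. Compound 4 `Cc1cc(C#N)cc(C)c1Oc1nc(Nc2ccc(C#N)cc2)ncc1-c1ccoc1` is not yet measured; it differs from compound 1 by furan-3-yl in place of pyridin-4-yl on an aromatic carbon. The measured step that bears most directly on this change is an at least 10-fold higher number from compound 1 to compound 3 (1.03 log units; beyond the scatter), and the parallel step an at least 36-fold higher number from compound 2 to compound 3 (1.55 log units; beyond the scatter) points the same way, both ending at the limit of > 306000 nM in this assay, at which 1 of the 3 values shown sits. A large upward step is therefore expected for compound 4, a 7.1-fold higher number from compound 1 to compound 4 (0.85 log units; beyond the scatter). Compound 4 is estimated at 200000 nM, within 60000 nM to 400000 nM, with a fair chance that only a limit is reported.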

Compound 4, half-maximal cytotoxic concentration: 4980 nM
Beside the measured number, compound 4's estimate is 40-fold (1.60 log units) above it; measured number below the stated range.
By their numbers in this assay, from the lowest: compounds 4 and 2 (each within the scatter of the next); then compound 1. At a limit, above all of these: compound 3.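

Moving the furan attachment from furan-2-yl to furan-3-yl changes the outcome at this position in this assay, with an at least 61-fold lower number from compound 3 to compound 4 (1.78 log units; beyond the scatter). Compound 3 is a limit, not a number: the limit of > 306000 nM in this assay, at which 1 of the 4 values shown sits. Furan-3-yl does not share the upward move seen with furan-2-yl, giving a 5.6-fold lower number from compound 1 to compound 4 (0.75 log units; beyond the scatter), and with a 1.7-fold lower number from compound 2 to compound 4 (0.23 log units; within the scatter) compound 2 and compound 4 cannot be told apart.

As far as these compounds go, it remains open whether the result for compound 3 is particular to furan-2-yl or also holds for thiophen-2-yl. From the compounds shown here alone, the effect of a non-aromatic group here, such as an amine, also remains open.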